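Chloro for cyano on a weak urea pair

A few compounds are considered here, and "the series" means these few. Any claim that something is new, unique, unknown or untested is made for them only; others in the source may bear on it.

Measured so far:
compound 1, `CCCCCNC(=O)Nc1nc2ccc([N+](=O)[O-])cc2s1`, in a functional assay (thoracic aorta, Rattus norvegicus, strain Wistar) (on this read-out lower numbers stand for an effect already at smaller amounts and higher numbers for an effect only at larger amounts of compound), gives 2110 nM.
compound 2, `N#Cc1ccc(NC(=O)Nc2nc3c(s2)CCCC3)cc1`, in this assay gives > 100000 nM.

Of these two values, only compound 1 carries a plain number. For compound 2 the read-out stops at the limit of the assay, so its entry is not a number but a boundary. Compound 2 thus stands at the limit of > 100000 nM in this assay, at which 1 of the 2 values shown sits, the weak end of what the assay can report. Going by the values given here, no step between compound 1 and compound 2 has been worked out, and the two differ in more than one place, so nothing beyond their two values can be said about them together.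

Compound 3, `O=C(Nc1ccc(Cl)cc1)Nc1nc2c(s1)CCCC2`, is the next candidate. It differs from compound 2 by a single swap: chloro in place of cyano on an aromatic carbon, counted as chloro in place of cyano on an aromatic carbon. With compound 2 already at a limit, the step expected here, a number no higher from compound 2 to compound 3 (the limit leaves the size open), is likely none beyond the scatter, and compound 3 may well remain at the limit. Compound 3 is therefore estimated at 100000 nM, within a range from 20000 nM to 300000 nM.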

Compound 3, half-maximal effective concentration: > 100000 nM
Compound 3: a limit, no number; the forecaster's own chance of this, stated with the estimate: 60%; the middle value lies on the limit itself.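

Compound 3 gives > 100000 nM in this assay, which is a limit and not a number. Compound 2 sits at the same limit, so no step can be read between compound 2 and compound 3: the limit of > 100000 nM in this assay, at which 2 of the 3 values shown sit. As far as these compounds go, whether chloro in place of cyano changes the effect at all stays open.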